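The source may hold more compounds than are shown below. What is called first, only, known or untested is meant among the compounds shown, and "the series" means these compounds.

Compound 1 `CCC(CC)(c1ccc(OS(=O)(=O)c2ccc(C)cc2)c(C)c1)c1ccc(OCC(=O)C(C)(C)C)c(OCC(=O)C(C)(C)C)c1`: 35%
Compound 2 `CCC(CC)(c1ccc(OS(=O)(=O)c2ccc(C)cc2)c(C)c1)c1ccc(OCC(O)C(C)(C)C)c(OCC(O)C(C)(C)C)c1`: 43%

In an assay on cells for binding affinity to vitamin D3 receptor (Homo sapiens), read by fluorescence, tested at 1 uM (on this read-out lower numbers stand for less inhibition and higher numbers for more inhibition at the one concentration tested (going by the name of the read-out)), compound 1 gives 35%, while compound 2 gives 43%. Compound 2 stands highest of the two numbers, but its nearest neighbour, compound 1, lies lower by an amount within the scatter, so the two readings cannot be ordered against each other. Within the data shown here, no step between measured compounds that differ in one place is available for comparison.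

Compound 3 `CCC(CC)(c1ccc(OCC(O)CO)c(C)c1)c1ccc(OCC(O)C(C)(C)C)c(OCC(O)C(C)(C)C)c1` is the next compound and differs from compound 2 in one place: 2,3-dihydroxypropyl in place of (4-methylphenyl)sulfonyl on an oxygen on an aromatic ring. Among the measured compounds shown here, nothing measured so far bears on this kind of exchange, so the direction of the step is open. Compound 3 is expected to give 38% in this assay, with a plausible range from 15% to 65%. The expected step of a number 5 percentage points lower from compound 2 to compound 3 (within the scatter) is estimated to stay within the scatter, with no change beyond it.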

Compound 3, a percentage reported as inhibition, at one concentration (the size of the read-out at that concentration, not a potency): 78%
Compound 3: the middle estimate sits 40 percentage points below what was measured; the measured number lies above the stated range.
By their numbers in this assay, from the lowest: compounds 1 and 2 (each within the scatter of the next); then compound 3.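

In this assay, the oxygen on the aromatic ring turns out to be a place that responds strongly to what it carries: 2,3-dihydroxypropyl in place of (4-methylphenyl)sulfonyl gives a number 35 percentage points higher from compound 2 to compound 3 (beyond the scatter), so the ring-bearing sulfonyl group is not needed for this level of inhibition at the one concentration tested. The exchange swaps that group for a smaller chain with no ring and with hydrogen-bond donors, which the departing group lacks. Nothing available here accounts for the size of the step.

The compounds shown leave open whether the loss of the sulfonyl group or the arrival of the two hydroxyl groups matters more. A methyl ether, a 2-hydroxyethyl chain, a longer diol chain, an amine or a carboxylic acid on the same oxygen would help separate the two.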